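B1 bradykinin receptor binding: step from compound 2 to compound 4

The source may report more compounds than this note shows. Statements on the series, on what has been measured and on what is new or still open speak of the compounds shown alone.

Measured compounds, with their values in an assay on HEK293 cells for displacement of a labelled ligand from B1 bradykinin receptor (Homo sapiens), read by scintillation counting; a higher number here means a weaker inhibitor, a lower number a stronger inhibitor:
compound 1 `COc1cc(C)c(S(=O)(=O)N(C)CCOCC(=O)N2CCC(C(C)(C)CN(C)C)CC2)c(C)c1` gives 10 nM
compound 2 `CCN(CC)CCN1CCN(C(=O)COCCN(C)S(=O)(=O)c2c(C)cc(OC)cc2C)CC1` gives 10 nM
compound 3 `Cc1c(Cl)ccc(S(=O)(=O)N(C)CC(=O)NCC(=O)N(C)Cc2ccc(C3=NCCN3)cc2)c1Cl` gives 78 nM

Compound 2 stands level with compound 1 at the digits shown, and the two together hold the lowest numbers of the three. Its nearest neighbour is compound 1, with no change at the digits shown and within the scatter; its furthest is compound 3, whose number lies a good way higher and beyond the scatter.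

Compound 4 `COc1cc(C)c(S(=O)(=O)N(C)CCOCC(=O)N2CCN(CC3CCN(C)CC3)CC2)c(C)c1` is not yet measured in this assay. Against compound 2 the change is 1-methylpiperidin-4-yl in place of (diethylamino)methyl on a saturated chain carbon bound to an amine nitrogen in a ring. Going by the values given here, no pair of measured compounds differing in a single place is available, so the size of this step has no direct precedent in the set. What the set does show is that compound 1 and compound 2, which share the same core and differ in the amine-bearing end, stand level in this assay; compound 4 keeps that core and again ends in a group with one amine nitrogen. The expectation is therefore a step of no more than the scatter, with no clear direction.

Compound 4 is expected to give 12 nM, in the range 4 nM to 40 nM, which means an expected step of a 1.2-fold higher number from compound 2 to compound 4 (0.08 log units; within the scatter) that stays within the scatter.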

Compound 4, inhibition constant: 4.5 nM
For compound 4 the middle estimate is 2.7-fold (0.43 log units) above the measured one; the measured number falls inside the stated range.
By their numbers in this assay, from the lowest: compound 4; then compounds 1 and 2 (each within the scatter of the next); then compound 3.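

In this assay, going by these compounds alone, 1-methylpiperidin-4-yl in place of (diethylamino)methyl on a saturated chain carbon bound to an amine nitrogen in a ring gives a 2.2-fold lower number from compound 2 to compound 4 (0.35 log units; beyond the scatter), the first single-place step in the set, modest in size but beyond the scatter. Read one bond further out, as 2-(diethylamino)ethyl to (1-methylpiperidin-4-yl)methyl, it shows that at this place an amine end without a ring can give way to one held in a six-membered non-aromatic ring with 1 hetero atom, with the counts of hydrogen-bond donors and acceptors unchanged and the number falling rather than rising. Nothing measured on these compounds speaks to the reason for this step.

Going by these compounds, whether the fall goes with the ring or with the amine nitrogen it carries stays open, and a cyclohexyl or morpholin-4-yl group at the same place would separate the two. Also open, on these data alone, is how a 1-methylpyrrolidin-3-yl ring or a longer chain to the amine would read here, and whether the step carries over to other amine ends.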